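Quinolinone carboxamides: aryl replacement at the bromo position

The compounds below may be only part of what the source reports. "The series", "measured", "known", "first", "only" and "open" are said of these compounds alone.

Measured so far, in a functional assay on KYSE-70 cells for antiproliferative activity against KYSE-70 cell line (Homo sapiens), read by MTT assay, with a stated time of 72 h; on this read-out lower numbers stand for stronger inhibition and higher numbers for weaker inhibition:
- compound 1 `O=C(Nc1cccc(F)c1)c1cc(=O)[nH]c2cc(Br)ccc12`: 8900 nM
- compound 2 `O=C(Nc1cccc(F)c1)c1cc(=O)[nH]c2cc(-c3ccc(F)cc3)ccc12`: 3300 nM
- compound 3 `O=C(Nc1cccc(F)c1)c1cc(=O)[nH]c2cc(-c3ccncc3)ccc12`: only a limit, > 20000 nM

Compound 3 carries pyridin-4-yl on the shared core and sits at the limit of this assay, so its number is not known; of the three values shown it is the only one at the limit of > 20000 nM in this assay, at which 1 of the 3 values shown sits. Compound 1 gives 8900 nM, and compound 2, with 4-fluorophenyl in the same place, gives 3300 nM, so the aryl group matters: a 2.7-fold lower number from compound 1 to compound 2 (0.43 log units; beyond the scatter), whereas an at least 2.2-fold higher number from compound 1 to compound 3 (0.35 log units; beyond the scatter) and an at least 6.0-fold higher number from compound 2 to compound 3 (0.78 log units; beyond the scatter).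

Compound 4 `Cc1cc(-c2ccc3c(C(=O)Nc4cccc(F)c4)cc(=O)[nH]c3c2)c(C)cc1F` is not yet measured. It differs from compound 3 by 4-fluoro-2,5-dimethylphenyl in place of pyridin-4-yl on an aromatic carbon. Among the compounds with values here, the step that bears on this change is the one from compound 2 to compound 3, since compound 4 returns to a carbon-only six-membered ring bearing fluorine, now with two added methyl groups. That step was an at least 6.0-fold higher number from compound 2 to compound 3 (0.78 log units; beyond the scatter), so a step of similar size in the opposite direction is expected here, with no separate evidence on the methyl groups. The expected step is an at least 5.0-fold lower number from compound 3 to compound 4 (0.69 log units; beyond the scatter). Compound 4 is therefore estimated at 4000 nM, with a range from 1200 nM to 14000 nM.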

Compound 4, half-maximal inhibitory concentration: > 20000 nM
Compound 4 ended at the assay's limit; the forecaster's own chance of this, stated with the estimate: 10%; middle value at least 5.0-fold (0.69 log units) away from the limit.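

In this assay compound 4 gives > 20000 nM, which is a limit of the assay and not a number, and with compound 3 also at a limit, the step between these two cannot be read: the limit of > 20000 nM in this assay, at which 2 of the 4 values shown sit.

The fluorine-bearing ring of carbon only does not by itself keep the activity at this position, since 4-fluoro-2,5-dimethylphenyl in place of 4-fluorophenyl gives an at least 6.0-fold higher number from compound 2 to compound 4 (0.78 log units; beyond the scatter). Against the bromo group, the same substituent gives an at least 2.2-fold higher number from compound 1 to compound 4 (0.35 log units; beyond the scatter), so the loss is no longer confined to the ring with a hetero atom, and of the three aryl groups shown only the 4-fluorophenyl of compound 2 gives a lower number than compound 1.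

Open, going by these compounds, is whether a single methyl group would be enough for the step from compound 2 to compound 4, and which of the two would carry it. Also open, on these data alone, is how the 4-fluorophenyl ring of compound 2 would read with an amine such as dimethylamino or with a carboxylic acid in place of the fluorine.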